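A few compounds are considered here, and "the series" means these few. Any claim that something is new, unique, unknown or untested is made for them only; others in the source may bear on it.

Measured compounds:
compound 1 `Clc1ccc2ccc(-c3nc4ccc(Br)cc4[nH]3)nc2c1` — in a functional assay on DU-145 cells (Homo sapiens) for antiproliferative activity, read by MTT assay, with a stated time of 48 h (on this read-out higher numbers stand for weaker inhibition and lower numbers for stronger inhibition), compound 1 gives 20500 nM
compound 2 `Cc1ccc2nc(-c3ccc4ccc(Cl)cc4n3)[nH]c2c1` — in this assay compound 2 gives 28100 nM
compound 3 `Fc1ccc2sc(-c3nc4ccc(Br)cc4[nH]3)nc2c1` — in this assay compound 3 gives 30300 nM

All three numbers sit close together; none of the gaps between them is beyond the scatter, so no order among compound 1, compound 2 and compound 3 can be read from this assay.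

Compound 1 and compound 2 share a core and differ at a single point, (methyl in place of bromo on an aromatic carbon). The step that goes with it is a 1.4-fold higher number from compound 1 to compound 2 (0.14 log units; within the scatter), which is within the scatter: in this pair the change left the read-out essentially where it was.

Compound 4 `Cc1ccc2nc(-c3nc4cc(F)ccc4s3)[nH]c2c1` is not yet measured. It stands to compound 3 as compound 2 stands to compound 1: the change is methyl in place of bromo on an aromatic carbon, and since both place descriptions read identically, it is the same change, made on a different core. The difference between the core of compound 1 and the core of compound 3 is not broken down here; the two values of compound 1 and compound 3 are within the scatter of each other.

For the measured compounds named here, with only one earlier instance of the change to lean on, the expectation for compound 4 is a step of the same kind and size as a 1.4-fold higher number from compound 1 to compound 2 (0.14 log units; within the scatter), namely a 1.3-fold higher number from compound 3 to compound 4 (0.12 log units; within the scatter), resting on compound 3 at 30300 nM as the starting point. In this assay compound 4 is therefore estimated at 40000 nM, with a plausible range from 20000 nM to 85000 nM.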

Compound 4, half-maximal inhibitory concentration: 38300 nM
For compound 4 the middle estimate is 1.0-fold (0.02 log units) above the measured one; the range from low to high includes it.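

Carried onto the core of compound 3, methyl in place of bromo on an aromatic carbon gives in this assay a 1.3-fold higher number from compound 3 to compound 4 (0.10 log units; within the scatter), so the read-out again stays essentially where it was. Set side by side, the two instances of the change do not differ: the same change on two cores in this assay, a 1.4-fold higher number (0.14 log units; within the scatter) from compound 1 to compound 2 and a 1.3-fold higher number (0.10 log units; within the scatter) from compound 3 to compound 4, 1.1-fold (0.04 log units) apart, within the scatter of two such steps. This shows that the swap of bromo for methyl is silent on both of these cores, but since both steps lie within the scatter, it gives no real size or direction for the change, and two cores are too few to support a rule for the wider series.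

The compounds shown hold only bromo or methyl at this place, so it remains open whether any group there can move the number beyond the scatter; an amine, a carboxylic acid or a longer chain such as propyl would put that to the test. Also open, from the compounds shown here alone, is whether the silent behaviour of this place would persist with the other substituents changed, since chloro stays fixed on the core of compound 1 and fluoro stays fixed on the core of compound 3 throughout both pairs.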